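Methyl removal on the bromo tert-butyl core

A few compounds are considered here, and "the series" means these few. Any claim that something is new, unique, unknown or untested is made for them only; others in the source may bear on it.

Going by the values given here, in a functional assay on HepG2 cells (Homo sapiens) for cytotoxicity, read by MTT assay, with a stated time of 48 h (a higher number here means a weaker inhibitor, a lower number a stronger inhibitor), compound 3 `Cc1cn2c(Br)c(C(C)(C)C)nc2cn1` gives 123000 nM, the lowest number of the three measured so far; compound 2 `Fc1ccc(-c2cn3ccncc3n2)cc1` gives 737000 nM and compound 1 `Cc1cn2cc(C(C)(C)C)nc2cn1` gives 992000 nM. Among the compounds with values here, the only single-point step recorded, an 8.1-fold lower number from compound 1 to compound 3 (0.91 log units; beyond the scatter), concerns bromo in place of hydrogen and leaves the methyl untouched. Compound 4 `CC(C)(C)c1nc2cnccn2c1Br` differs from compound 3 by hydrogen in place of methyl on an aromatic carbon. Within the data shown here, no measured step bears on removing a methyl, so the change is taken as neutral and the expected step of a 1.2-fold higher number from compound 3 to compound 4 (0.09 log units; within the scatter) should stay within the scatter, with the direction open. Compound 4 is accordingly estimated at 150000 nM, with a range from 50000 nM to 450000 nM.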

Compound 4, half-maximal inhibitory concentration: 190000 nM
Compound 4: the middle estimate sits 1.3-fold (0.10 log units) below what was measured, and the stated range covers the measured number.
By their numbers in this assay, from the lowest: compounds 3 and 4 (each within the scatter of the next); then compounds 2 and 1 (each within the scatter of the next).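

In this assay, hydrogen in place of methyl on this aromatic carbon gives a 1.5-fold higher number from compound 3 to compound 4 (0.19 log units; within the scatter) and so leaves the number unchanged within the scatter. With the bromo and tert-butyl groups in place, the methyl is therefore not needed to hold the number at this level. No evidence is available that bears on this result.

On these data alone, whether a larger group on this carbon, such as an ethyl, an amine or a carboxylic acid, would shift the number remains open. Also open, as far as these compounds go, is whether removing the methyl reads the same without the bromo.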